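Can a urea-type group swap reverse the last step?

The source may hold more compounds than are shown below. What is called first, only, known or untested is meant among the compounds shown, and "the series" means these compounds.

Values so far in a functional assay on L1210 cells (Mus musculus) for inhibition, read by MTT assay, with a stated time of 72 h; on this read-out lower numbers stand for stronger inhibition and higher numbers for weaker inhibition
Compound 1 `COc1cc(NC(C)CCCNC(=O)NNC(=O)Nc2ccc(F)cc2)c2ncccc2c1` gives 104000 nM
Compound 2 `COc1cc(NC(C)CCCNC(=O)Nc2cccc(O)c2)c2ncccc2c1` gives 25000 nM
Compound 3 `COc1cc(NC(C)CCCNC(=O)NNC(=O)Nc2cccc(F)c2)c2ncccc2c1` has not yet been measured

Going by the values given here, compound 2 holds the lower of the two numbers so far. Going on to compound 3 brings the change ((3-fluorophenyl)carbamoyl)amino in place of 3-hydroxyphenyl on an amide-type nitrogen in which ((3-fluorophenyl)carbamoyl)amino takes the place of 3-hydroxyphenyl on an amide-type nitrogen. The measured step of a 4.2-fold lower number from compound 1 to compound 2 (0.62 log units; beyond the scatter) bears on this change and ran nearly the reverse way. A step of similar size toward a higher number is therefore expected in this assay for compound 3, though one step is thin support. The expected move is a 3.6-fold higher number from compound 2 to compound 3 (0.56 log units; beyond the scatter) on this estimate. Compound 3 is estimated at 90000 nM with an expected range from 35000 nM to 200000 nM in this read-out.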

Compound 3, half-maximal inhibitory concentration: 108000 nM
For compound 3 the middle estimate is 1.2-fold (0.08 log units) below the measured one, and the stated range covers the measured number.
By their numbers in this assay, from the lowest: compound 2; then compounds 1 and 3 (each within the scatter of the next).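

In this assay, ((3-fluorophenyl)carbamoyl)amino in place of 3-hydroxyphenyl gives a 4.3-fold higher number from compound 2 to compound 3 (0.64 log units; beyond the scatter), so this longer group undoes the earlier step with a second fluorophenyl version. With 3-fluorophenyl in place of 4-fluorophenyl there is a 1.0-fold higher number from compound 1 to compound 3 (0.02 log units; within the scatter), so these two fluorophenyl groups cannot be told apart here. No measurement offered here explains these results.

Going by these compounds, the swap changes the linker and the ring substituent together, so their separate contributions remain open. A plain phenyl or a 3-fluorophenyl placed directly on the amide-type nitrogen would help separate them.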